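The source may hold more compounds than are shown below. What is called first, only, known or untested is meant among the compounds shown, and "the series" means these compounds.

Three compounds have been measured so far in an ADME assay on NHDF cells (Homo sapiens) for cytotoxicity, read by MTT assay, with a stated time of 72 h; a lower number here means a stronger inhibitor, a higher number a weaker inhibitor
- compound 1 (`COc1ccc(/C=C2\CCC/C(=C\c3cccc(Cl)c3)C2=O)cc1OC`) at 11900 nM
- compound 2 (`COc1ccc(/C=C2\CCC/C(=C\c3ccccc3Br)C2=O)cc1OC`) at 21800 nM
- compound 3 (`COc1ccc(/C=C2\CCC/C(=C\c3ccc(OC)c(OC)c3)C2=O)cc1OC`) at 9700 nM

Compound 3 and compound 1 lie within the scatter of each other, while compound 2 sits beyond the scatter from compound 3, with the higher number. Compound 4 (`COc1cc(/C=C2\CCC/C(=C\c3ccc(OC)c(OC)c3)C2=O)ccc1O`) has not yet been measured. It differs from compound 3 in one place (hydrogen in place of methyl on an oxygen on an aromatic ring), with hydrogen in place of methyl on an oxygen on an aromatic ring, a change that reads as methoxy to hydroxy.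

For the measured compounds named here, no measured step covers this change. Going by the values given here, the only step available (a 1.8-fold higher number from compound 1 to compound 2 (0.26 log units; within the scatter)) puts 2-bromophenyl in place of 3-chlorophenyl, which is a different swap, so it bears on the question only indirectly. It shows one structural change that left the number within the scatter. With that single step as a guide, no shift beyond the scatter is expected in this assay, and the data favour no direction. The expected step (a 1.1-fold lower number from compound 3 to compound 4 (0.06 log units; within the scatter)) is therefore small, and this estimate rests on very little evidence. For compound 4 the estimated value is 8500 nM (expected range 3800 nM to 19000 nM).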

Compound 4, half-maximal inhibitory concentration: 13700 nM
Compound 4: the middle estimate sits 1.6-fold (0.21 log units) below what was measured; measured number inside the range.
By their numbers in this assay, from the lowest: compounds 3, 1, 4 and 2 (each within the scatter of the next, the first and the last beyond it).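

In this assay, for the compounds shown here, this is the first measured case of taking the methyl off an oxygen on an aromatic ring, leaving a hydroxy where a methoxy stood (a 1.4-fold higher number from compound 3 to compound 4 (0.15 log units; within the scatter)), and that step stays within the usual scatter of repeated measurements. The resulting 4-hydroxy-3-methoxyphenyl group also lies within the scatter of the 2-bromophenyl group (a 1.6-fold lower number from compound 2 to compound 4 (0.20 log units; within the scatter)) and of the 3-chlorophenyl group (a 1.2-fold higher number from compound 1 to compound 4 (0.06 log units; within the scatter)), so none of the three steps that reach compound 4 can be told apart from measurement noise, and a free hydroxy on this ring gives no measurable separation from these groups. No accompanying measurement bears on the reason behind these numbers.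

On these data alone, the methoxy-to-hydroxy swap is seen here only once, on the background of compound 3, so whether it behaves the same way on other members remains open. Also open, as far as these compounds go, is whether a longer chain on that oxygen, such as ethyl, or an amine or a carboxylic acid at the same place, would shift the number beyond the scatter in this assay.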